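The compounds below may be only part of what the source reports. "The series", "measured", "known", "first", "only" and "open" are said of these compounds alone.

Working notes on the series.

Compound 1 `Cn1c(Cc2nn(C)c(=O)c3ccccc23)nnc1SCCCCCCCC(=O)Nc1ccc(Cl)cc1Cl` is the parent; in an assay on 32D cells for inhibition of interleukin-15 (Mus musculus), read by resazurin assay, with stated times of 30 min and 2.5 days, in the presence of a further agent that is not named here (on this read-out lower numbers stand for stronger inhibition and higher numbers for weaker inhibition), compound 1 gives 2200 nM. Compound 2 `Cn1nc(Cc2nnc(SCCCCCCCC(=O)Nc3ccc(Cl)cc3Cl)n2CCC=O)c2ccccc2c1=O` carries formylmethyl on a saturated chain carbon bound to an aromatic nitrogen where compound 1 has hydrogen; in this assay compound 2 gives 2500 nM. Within the data shown here, the only measured step, a 1.1-fold higher number from compound 1 to compound 2 (0.06 log units; within the scatter), shows that this addition left the read-out essentially unchanged. Among the measured compounds shown here, compound 2 thus stands at the higher of the two numbers so far, with compound 1 as its only neighbour and within the scatter of it, so no ordering between the two can be claimed.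

Compound 3 `Cn1nc(Cc2nnc(SCCCCCCCC(=O)Nc3ccc(Cl)cc3Cl)n2CCCO[Si](C)(C)C(C)(C)C)c2ccccc2c1=O` is the next change on the same side of the shared core: a group of 9 heavy atoms (7 carbon, 1 oxygen, 1 silicon; no ring) in place of a group of 2 heavy atoms (1 carbon, 1 oxygen; no ring), on a saturated chain carbon, two bonds along the chain from an aromatic nitrogen. Only a 1.1-fold higher number from compound 1 to compound 2 (0.06 log units; within the scatter) bears on this position, and it was within the scatter; the entering group is considerably larger than anything tested there, so the precedent is thin. The expectation for compound 3 is a step of a 1.1-fold higher number from compound 2 to compound 3 (0.05 log units; within the scatter), not beyond the scatter. Compound 3 is estimated at 2800 nM, with a range of 1100 nM to 7500 nM.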

Compound 3, half-maximal inhibitory concentration: > 30000 nM
Compound 3: a limit, no number; the forecaster's own chance of this, stated with the estimate: 5%; middle value at least 10-fold (1.02 log units) from the limit.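

Compound 3 in this assay is a limit and not a number: the limit of > 30000 nM in this assay, at which 1 of the 3 values shown sits.

At this place, on a saturated chain carbon, two bonds along the chain from an aromatic nitrogen, exchanging formyl for the group of 9 heavy atoms (7 carbon, 1 oxygen, 1 silicon; no ring) gives an at least 12-fold higher number from compound 2 to compound 3 (1.07 log units; beyond the scatter), and the whole addition measured against the parent gives an at least 13-fold higher number from compound 1 to compound 3 (1.13 log units; beyond the scatter). Compound 2 alone had shown only that a substituent on this chain can leave the read-out essentially unchanged, whereas compound 3 shows that the read-out at this position depends on which group is carried.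

With only two groups compared here, the compounds shown leave open whether the size of the entering group, its silicon atom or some other feature of it goes with the step. A plain carbon chain of similar length, a free hydroxyl, an amine or a carboxylic acid at the same place would help separate these readings and show where along this range the read-out begins to move.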